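Chloro added to the phenoxy ring of compound 1

A few compounds are considered here, and "the series" means these few. Any claim that something is new, unique, unknown or untested is made for them only; others in the source may bear on it.

Measured so far in a functional assay on the whole organism with Mus musculus as the target, in the maximal electroshock model, with a stated time of 30 min; on this read-out lower numbers stand for an effect already at smaller amounts and higher numbers for an effect only at larger amounts of compound:
compound 1, `Cc1cc[n+]([O-])cc1Oc1ccccc1`: 30 mg/kg
compound 2, `[O-][n+]1ccc(Cl)c(Oc2ccccc2)c1`: > 300 mg/kg, which is a limit of the assay, not a number

Going by the values given here, compound 1 stands as the only number in this assay; the one other value, that of compound 2, sits at the limit (the limit of > 300 mg/kg in this assay, at which 1 of the 2 values shown sits). Among the compounds with values here, the only measured step is an at least 10-fold higher number from compound 1 to compound 2 (1.00 log units; beyond the scatter), where chloro replaced methyl on the shared core of compound 1. Compound 3, `Cc1cc[n+]([O-])cc1Oc1ccc(Cl)cc1`, is not yet measured. It differs from compound 1 thus: chloro in place of hydrogen on an aromatic carbon. Here methyl stays on the core and chloro enters on the other six-membered ring, so the measured step bears on this change only loosely: it shows that a chloro in one place of the series can push the number past the limit, but not what a chloro elsewhere does. Within the data shown here, no step tests a change on the phenoxy ring. A step in this assay for compound 3 is therefore expected to be small, at most modestly upward, likely within the scatter; the expected step of a 1.7-fold higher number from compound 1 to compound 3 (0.22 log units; within the scatter) is taken as a slight rise. Compound 3 is estimated at 50 mg/kg, between 20 mg/kg and 150 mg/kg.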

Compound 3, minimum effective dose: 100 mg/kg
Compound 3: the middle estimate sits 2.0-fold (0.30 log units) below what was measured, within the range that was stated.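

In this assay, going by these compounds alone, the first change on the six-membered aromatic ring of carbon only gives a 3.3-fold higher number from compound 1 to compound 3 (0.52 log units; beyond the scatter), with chloro in place of hydrogen on an aromatic carbon para to a group of 9 heavy atoms. This position is therefore not indifferent to substitution: a single chlorine raises the dose needed, yet compound 3 still gives a number in this assay, so an effect remains on this read-out. Compound 2 remains the only compound held at a limit of the assay, and its value is not a number: the limit of > 300 mg/kg in this assay, at which 1 of the 3 values shown sits.

The compounds shown leave open whether the rise belongs to chloro itself or would follow any group at this place, since a fluoro, a methoxy, an amine or a carboxylic acid at the same carbon stands outside them. They also leave open how chloro acts at other carbons of this ring, and whether any change on this ring can lower the number below that of compound 1, 30 mg/kg.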